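Series notes: from compound 1 to compound 4

The source may hold more compounds than are shown below. What is called first, only, known or untested is meant among the compounds shown, and "the series" means these compounds.

Measured so far: compound 1 `N#Cc1ccccc1OC1CCN(c2ccc(-n3ccnc3)nn2)CC1` gives 236 nM in an assay on microsomes from liver for inhibition of acyl-CoA desaturase 1 (Rattus norvegicus); on this read-out lower numbers stand for stronger inhibition and higher numbers for weaker inhibition; compound 2 `Oc1nnc(-c2ccc(N3CCC(Oc4ccccc4C(F)(F)F)CC3)nn2)s1` gives 6.1 nM; compound 3 `CC(C)(C)c1nnc(-c2ccc(N3CCC(Oc4ccccc4C(F)(F)F)CC3)nn2)o1` gives 980 nM.

Compound 1 stands second highest of the three numbers, with compound 3 higher and compound 2 well lower. Compound 4 `c1cc(OC2CCN(c3ccc(-n4ccnc4)nn3)CC2)c2cc[nH]c2c1` differs from compound 1 by 1H-indol-4-yl in place of 2-cyanophenyl on an oxygen on a saturated carbon. Going by the values given here, the only measured step, a 160-fold higher number from compound 2 to compound 3 (2.21 log units; beyond the scatter), changes the group on an aromatic carbon and leaves the group on the oxygen on the saturated carbon unchanged, so it does not bear on this change. Among the compounds with values here, no measured pair shows how that group governs this assay. For compound 4 a number close to that of compound 1 is therefore expected, a step of a 1.5-fold lower number from compound 1 to compound 4 (0.17 log units; within the scatter). The estimate for compound 4 is 160 nM, range 40 nM to 650 nM.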

Compound 4, half-maximal inhibitory concentration: 162 nM
Compound 4: middle estimate off by 1.0-fold (0.01 log units), on the low side, and the stated range covers the measured number.
By their numbers in this assay, from the lowest: compound 2; then compounds 4 and 1 (each within the scatter of the next); then compound 3.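

Going by these compounds alone, on the oxygen on a saturated carbon, 1H-indol-4-yl in place of 2-cyanophenyl gives a 1.5-fold lower number from compound 1 to compound 4 (0.16 log units; within the scatter) in this assay and is the first measured pair at this position. Here, a group with a five-membered aromatic ring and a hydrogen-bond donor, without the nitrile, leaves the number within the scatter. Nothing measured explains this result.

Going by these compounds, whether a carboxylic acid or an open-chain amine on that oxygen would keep the number in this range remains open. So does whether the same holds alongside the 5-hydroxy-1,3,4-thiadiazol-2-yl group of compound 2.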